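The compounds below may be only part of what the source reports. "The series", "measured", "known", "first", "only" and "open" are said of these compounds alone.

Of the compounds shown here, two have so far been measured in a functional assay on SK-BR-3 cells (Homo sapiens) for antiproliferative activity, read by MTT assay, with a stated time of 72 h; a higher number here means a weaker inhibitor, a lower number a stronger inhibitor. Compound 1 `CCN1CCN(c2cc(C)c3cc(NC(=O)c4cccc(C)c4)ccc3n2)CC1` gives 13700 nM, the lower of the two numbers. Compound 2 `CCN(CC)c1cc(C)c2cc(NC(=O)c3ccc(Cl)c(Cl)c3)ccc2n1` gives 41200 nM in this assay, a higher number than compound 1 shows. Going by the values given here, no single-point step connects these two compounds, so their values can only be set side by side.

Compound 3 `CCN1CCN(c2cc(C)c3cc(NC(=O)c4cccc(Br)c4)ccc3n2)CC1` has not yet been measured. It differs from compound 1 in one place: bromo in place of methyl on an aromatic carbon. Among the compounds with values here, one heavy atom replaces another at the same position of the same ring, and no measured pair shows how such an exchange plays out in this assay. The step is expected to stay within the usual scatter, in either direction, and a 1.1-fold lower number from compound 1 to compound 3 (0.06 log units; within the scatter) is the estimated step. Compound 3 is therefore expected to give about 12000 nM in this assay, with a likely range from 5000 nM to 30000 nM.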

Compound 3, half-maximal inhibitory concentration: 13300 nM
Compound 3: the middle estimate sits 1.1-fold (0.04 log units) below what was measured; the range from low to high includes it.
By their numbers in this assay, from the lowest: compounds 3 and 1 (each within the scatter of the next); then compound 2.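

Bromo in place of methyl gives a 1.0-fold lower number from compound 1 to compound 3 (0.01 log units; within the scatter) in this assay so, at this place on the ring, the two groups cannot be told apart. This pair is the only single-point step among the compounds shown, and it adds what the side-by-side values of compound 1 and compound 2 could not: with the rest of the molecule held constant, 3-methylphenyl and 3-bromophenyl give matching results. Nothing measured on these compounds explains that match.

As far as these compounds go, whether the match extends beyond these two groups remains open: a carboxylic acid, a hydroxyl or a longer alkyl chain at this place could behave quite differently. Compound 2 differs from compound 1 in more than one place, so its higher number cannot be assigned to any single change.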